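Ethyl in place of methyl on the ring amide nitrogen

A few compounds are considered here, and "the series" means these few. Any claim that something is new, unique, unknown or untested is made for them only; others in the source may bear on it.

For the measured compounds named here, compound 2 `CN1C(=O)CN(C2CCCC2)c2nc(Nc3ccc(N4CCCCC4)cc3)ncc21` is the only compound of this set with a number in a functional assay on MDA-MB-231 cells (Homo sapiens) for inhibition, read by MTT assay, with a stated time of 48 h; a lower number here means a stronger inhibitor, a higher number a weaker inhibitor: there compound 2 gives 21200 nM. Compound 1 `CCN1C(=O)CN(C2CCCC2)c2nc(Nc3ccc(OC)cc3)ncc21` reaches only a limit of the assay, since in this assay compound 1 gives > 30000 nM. Compound 1 and compound 2 differ in two places, so their two values show no more than that one is a number and the other a limit, at the limit of > 30000 nM in this assay, at which 1 of the 2 values shown sits. Compound 3 `CCN1C(=O)CN(C2CCCC2)c2nc(Nc3ccc(N4CCCCC4)cc3)ncc21` is still to be measured in this assay. It differs from compound 2 by methyl in place of hydrogen on a saturated chain carbon bound to an amide-type nitrogen in a ring, a change that, cut one bond further out, reads methyl to ethyl. Going by the values given here, no step between measured compounds bears on this change, so the step is expected to be small, no larger than the scatter, and the move from a 1.2-fold higher number from compound 2 to compound 3 (0.07 log units; within the scatter) is an estimate. Compound 3 is therefore expected to give about 25000 nM, in a range from 10000 nM to 60000 nM, with a fair chance that only a limit is reported.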

Compound 3, half-maximal inhibitory concentration: > 30000 nM
Compound 3: no number, only a limit; the forecaster's own chance of this, stated with the estimate: 35%; middle value at least 1.2-fold (0.07 log units) from the limit.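

In this assay, for the compounds shown here, the change of methyl to ethyl gives the first step that can be read at this position, an at least 1.4-fold higher number from compound 2 to compound 3 (0.15 log units; that floor lies within the scatter). Compound 3 reaches only a limit, so this is a floor and not a measured size, and because that floor lies within the scatter, it does not establish that ethyl is worse than methyl here. The step between compound 1 and compound 3 cannot be read, and the ceiling of the assay restricts what these compounds can show: the limit of > 30000 nM in this assay, at which 2 of the 3 values shown sit.

The compounds shown leave open how a longer chain such as propyl, or a chain ending in an amine or a carboxylic acid, would read at this position. They also leave open whether any group there would give a number clear of the limit.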